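The source may hold more compounds than are shown below. What is called first, only, known or untested is meant among the compounds shown, and "the series" means these compounds.

Measured in a functional assay on MT4 cells (Homo sapiens) for antiproliferative activity, read by MTT assay, with a stated time of 96 h; on this read-out higher numbers stand for an effect only at larger amounts of compound and lower numbers for an effect already at smaller amounts:

- compound 1 `N#C/C(=C\c1c(-c2ccccc2)[nH]c2ccccc12)C(=O)c1cccs1`: 400 nM
- compound 2 `Cc1ccc(S(=O)(=O)/C(C#N)=C/c2c(-c3ccccc3)[nH]c3ccccc23)cc1`: 400 nM
- compound 3 `COc1ccc(-c2[nH]c3ccccc3c2/C=C(\C#N)S(=O)(=O)c2ccccc2)cc1`: 200 nM

Compound 3 carries the lowest of the three numbers, but its nearest neighbour, compound 1, and its furthest, compound 2, both sit within the usual scatter of it, so no order among the three can be read from these values. For the measured compounds named here, the three compounds share one core and differ in the group attached to the exocyclic double bond and in the substituent on the pendant six-membered ring; no pair differs in one place only, so no single step is available to calibrate the next change.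

Compound 4 `N#C/C(=C\c1c(-c2ccccc2)[nH]c2ccccc12)S(=O)(=O)c1ccccc1` is the unmeasured analogue. It differs from compound 3 as follows: hydrogen in place of methoxy on an aromatic carbon, which read one bond further out is 4-methoxyphenyl to phenyl.

With compound 2 giving 400 nM on a closely related sulfonyl framework, and all three numbers lying within scatter of one another, the change is expected to move the number little, if at all, beyond the scatter in this assay; the expected step from a 1.5-fold higher number from compound 3 to compound 4 (0.18 log units; within the scatter) is toward a slightly higher number. Compound 4 is therefore estimated at 300 nM, with a range from 120 nM to 800 nM.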

Compound 4, half-maximal effective concentration: 400 nM
The estimate for compound 4 lay 1.3-fold (0.12 log units) below the measured number; the measured number falls inside the stated range.
By their numbers in this assay, from the lowest: compounds 3, 1, 2 and 4 (each within the scatter of the next).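

In this assay, hydrogen in place of methoxy on the aromatic carbon of the phenyl attached to the core gives a 2.0-fold higher number from compound 3 to compound 4 (0.30 log units; within the scatter) and so leaves the number within the scatter, while hydrogen in place of methyl on the ring of the sulfonyl group gives no change at the digits printed from compound 2 to compound 4 (within the scatter) with the same outcome. Phenylsulfonyl in place of (thiophen-2-yl)carbonyl on the double-bonded chain carbon gives no change at the digits printed from compound 1 to compound 4 (within the scatter) and is the first single-place reading of that group, so all three changes now read as steps and none passes beyond the scatter. No measurement is at hand that bears on the size of these steps.

An amine or a carboxylic acid on either aromatic ring could still show whether these positions respond at all. Replacement of the nitrile by an amide or an ester also remains open.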